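A few compounds are considered here, and "the series" means these few. Any claim that something is new, unique, unknown or untested is made for them only; others in the source may bear on it.

Working notes on the series. Compound 1 `CCCn1c(-c2ccc(OC)cc2)cnc1NC(=O)c1ccc(F)cc1` carries a propyl chain on the aromatic nitrogen of the shared core. In a toxicity assay on THP-1 cells (Homo sapiens) for inhibition (a higher number here means that more compound is tolerated, a lower number that less compound is tolerated), compound 1 gives only a limit of the assay, > 100000 nM. Compound 2 `Cn1c(-c2ccccc2)cnc1NC(=O)c1ccc(Br)cc1` likewise gives a limit in this assay, > 100000 nM. Compound 3 `COc1ccc(-c2cnc(NC(=O)c3cc(-c4ccccn4)n[nH]3)n2C)cc1` also gives a limit in this assay, >= 50000 nM. All three measured values are thus limits, as the limit of > 100000 nM in this assay, at which 2 of the 3 values shown sit, and the limit of >= 50000 nM in this assay, at which 1 of the 3 values shown sits, summarise, so compound 1 cannot be placed above or below the others. Compound 4 `COc1ccc(-c2cnc(NC(=O)c3ccc(F)cc3)n2C)cc1` differs from compound 1 by hydrogen in place of ethyl on a saturated chain carbon bound to an aromatic nitrogen. Since compound 2 and compound 3 already carry methyl on the aromatic nitrogen and sit at limits, no step beyond the scatter is expected in this assay, in either direction. The expected step of a number no higher from compound 1 to compound 4 (the limit leaves the size open) is therefore none. Compound 4 is expected at 100000 nM, with a range from 50000 nM to 200000 nM.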

Compound 4, half-maximal cytotoxic concentration: >= 50000 nM
Compound 4 gave a limit, no number; the forecaster's own chance of this, stated with the estimate: 85%; the middle value is on the limit's open side.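

Compound 1 and compound 4 both give only limits in this assay, so no step can be read between them. The compounds shown leave open where the half-maximal cytotoxic concentration of any of them actually lies.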